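The source may hold more compounds than are shown below. What is called first, only, known or untested is meant among the compounds shown, and "the series" means these compounds.

Working notes on the series.

Three compounds are in hand. Compound 1 `O=S(=O)(Nc1ccncc1Nc1cccc(Br)c1)C(F)(F)F`, compound 2 `O=S(=O)(Nc1ccncc1Nc1ccc(F)c(Cl)c1)C(F)(F)F` and compound 3 `O=S(=O)(Nc1ccncc1Nc1ccc(F)c(Br)c1)C(F)(F)F` share a core and differ only in their halogen substitution. In a functional assay on the whole organism (strain Wistar) with Rattus norvegicus as the target, with stated times of 30 min and 4 h, at a dose of 10 mg/kg by the intraperitoneal route (on this read-out lower numbers stand for a weaker effect and higher numbers for a stronger effect at the one dose given), compound 2 gives 48.2%, compound 3 gives 41.2% and compound 1 gives 27.1%. The step of a number 7 percentage points lower from compound 2 to compound 3 (within the scatter) is within the scatter, so compound 2 and compound 3 are not separated here, the change between them being (chloro in place of bromo on an aromatic carbon). By contrast a number 14.1 percentage points lower from compound 3 to compound 1 (beyond the scatter) is beyond the scatter, the change being (hydrogen in place of fluoro on an aromatic carbon).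

Compound 4 `O=S(=O)(Nc1ccncc1Nc1cccc(Cl)c1)C(F)(F)F` is not yet measured in this assay. It arises from compound 2 by hydrogen in place of fluoro on an aromatic carbon, which is the same kind of change as from compound 3 to compound 1, with one difference around the place: in compound 4 the hydrogen enters ortho to a chloro group, in compound 1 ortho to a bromo group. The two cores differ by chloro in place of bromo on an aromatic carbon.

Going by the values given here, only one earlier instance of this kind of change exists, and it lay beyond the scatter. For compound 4 the expected step is a number 14.2 percentage points lower from compound 2 to compound 4 (beyond the scatter) in this assay, because compound 2 gives 48.2% and the same kind of change gave a number 14.1 percentage points lower from compound 3 to compound 1 (beyond the scatter). Compound 4 is therefore expected to give about 34%, with a range estimated from 20% to 47%.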

Compound 4, a percentage reported as activity, at one dose (the size of the read-out at that dose, not a potency): "not active" (no number reported)
Nothing numeric was reported for compound 4, and the estimate cannot be compared.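

Going by these compounds alone, compound 4 is recorded in this assay as not active, without a number, so no step from compound 2 to compound 4 can be read and the hydrogen in place of fluoro change cannot be sized on the chloro core. No measured evidence on the cause of this result is available. The compounds shown leave open whether compound 4 differs from compound 1 in this read-out.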